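Sulfonamide versus urea on the benzylic nitrogen

The source may report more compounds than this note shows. Statements on the series, on what has been measured and on what is new or still open speak of the compounds shown alone.

Measured so far:
compound 1 `CCCCc1ccc(CN(Cc2ccccc2)S(C)(=O)=O)c(=O)n1Cc1ccc(-c2ccccc2-c2nn[nH]n2)cc1` gives 41.2% in a functional assay on the whole organism (artery) for inhibition, with Rattus norvegicus as the target, at a dose of 3 mg/kg by the intraduodenal route; on this read-out lower numbers stand for less inhibition and higher numbers for more inhibition at the one dose given (going by the name of the read-out)
compound 2 `CCCCc1ccc(CNC(=O)NC2CCCCC2)c(=O)n1Cc1ccc(-c2ccccc2-c2nn[nH]n2)cc1` gives 0% in this assay

Compound 2 stands lowest of the two numbers shown; the nearest, compound 1, is higher by a number 41.2 percentage points lower from compound 1 to compound 2 (beyond the scatter), a large step beyond the scatter. Compound 3 `CCCCc1ccc(CN(C)S(C)(=O)=O)c(=O)n1Cc1ccc(-c2ccccc2-c2nn[nH]n2)cc1` differs from compound 2 by methyl(methylsulfonyl)amino in place of (cyclohexylcarbamoyl)amino on a saturated chain carbon bound to an aromatic carbon. For the measured compounds named here, the one measured step that bears on this is the reverse-direction change from compound 1 to compound 2, where methylsulfonyl-bearing nitrogen gave way to the urea with the loss just stated. Compound 3 restores a methylsulfonyl group on that nitrogen, so an upward step in this assay is expected, though compound 1 carries benzyl where compound 3 carries methyl, so full return is uncertain. The estimated step is a number 30 percentage points higher from compound 2 to compound 3 (beyond the scatter). Compound 3 is expected at 30%, within 5% to 55%.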

Compound 3, a percentage reported as inhibition, in the whole organism at one dose (the size of the read-out at that dose, not a potency): 83.4%
The estimate for compound 3 lay 53.4 percentage points below the measured number, and the stated range ends below it.
By their numbers in this assay, from the lowest: compound 2; then compound 1; then compound 3.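

In this assay methyl(methylsulfonyl)amino in place of (cyclohexylcarbamoyl)amino gives a number 83.4 percentage points higher from compound 2 to compound 3 (beyond the scatter) and so does more than undo the loss seen with the urea. Hydrogen in place of phenyl on a saturated chain carbon bound to a sulfonamide nitrogen gives a number 42.2 percentage points higher from compound 1 to compound 3 (beyond the scatter) and shows that, with methylsulfonyl held constant, the other substituent on this nitrogen strongly shapes the read-out. No measurement here explains either step. As far as these compounds go, whether an ethyl group on that nitrogen, or ethylsulfonyl in place of methylsulfonyl, keeps this level remains open.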